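Changing the Ring on the Aromatic Nitrogen of Compound 3

The source may report more compounds than this note shows. Statements on the series, on what has been measured and on what is new or still open speak of the compounds shown alone.

Three measured compounds share one core and differ only in the ring attached to an aromatic nitrogen. Compound 1 `O=C1COc2ccc(-c3nn(-c4ccc(F)cc4)cc3-c3ccccc3)cc2N1` gives 45.2% in a functional assay on DLD-1 cells (Homo sapiens) for cytotoxicity, read by colorimetric assay and MTT assay, with a stated time of 3 days, tested at 20 uM; on this read-out lower numbers stand for a stronger effect and higher numbers for a weaker effect at the one concentration tested. Compound 2 `COc1ccc(-n2cc(-c3ccccc3)c(-c3ccc4c(c3)NC(=O)CO4)n2)cc1` gives 35.6% in this assay, and compound 3 `O=C1COc2ccc(-c3nn(-c4cc(Cl)cc(Cl)c4)cc3-c3ccccc3)cc2N1` gives 52.2% in this assay. Compound 3 therefore holds the highest of the three numbers, which on this read-out means the weakest effect at the single concentration tested. The step of a number 7 percentage points higher from compound 1 to compound 3 (within the scatter) stays within the scatter, whereas the step of a number 16.6 percentage points higher from compound 2 to compound 3 (beyond the scatter) goes beyond it, so only compound 2 can be separated from compound 3 with any confidence.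

Compound 4 `O=C1COc2ccc(-c3nn(-c4ccccc4)cc3-c3ccccc3)cc2N1` carries the change (phenyl in place of 3,5-dichlorophenyl on an aromatic nitrogen). Among the compounds with values here, the steps that bear on this are the two that also exchanged the ring on the aromatic nitrogen, a number 7 percentage points higher from compound 1 to compound 3 (within the scatter) and a number 16.6 percentage points higher from compound 2 to compound 3 (beyond the scatter), one small and one modest, both moving the number upward into compound 3. Taking both chlorines away is expected to bring compound 4 back toward the numbers of compound 1 and compound 2, so a step of about a number 8.2 percentage points lower from compound 3 to compound 4 (within the scatter) is expected in this assay. The estimated value for compound 4 is 44%, with a range from 30% to 58%.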

Compound 4, a percentage reported as activity, at one concentration (the size of the read-out at that concentration, not a potency): 47.7%
For compound 4 the middle estimate is 3.7 percentage points below the measured one, within the range that was stated.
By their numbers in this assay, from the lowest: compounds 2, 1, 4 and 3 (each within the scatter of the next, the first and the last beyond it).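

In this assay the plain phenyl ring supplies the unsubstituted comparison that the first three compounds lacked. Hydrogen in place of both chlorines gives a number 4.5 percentage points lower from compound 3 to compound 4 (within the scatter) and hydrogen in place of fluoro gives a number 2.5 percentage points higher from compound 1 to compound 4 (within the scatter) so on this read-out neither the 3,5-dichlorophenyl ring of compound 3 nor the 4-fluorophenyl ring of compound 1 can be told apart from phenyl. Hydrogen in place of methoxy gives a number 12.1 percentage points higher from compound 2 to compound 4 (beyond the scatter) so among these four compounds only the 4-methoxyphenyl ring of compound 2 separates from phenyl, with the stronger effect at the single concentration tested.

As far as these compounds go, whether an amine, a carboxylic acid or a longer chain on this ring would also separate from phenyl remains open, as does whether such a group would follow the methoxy of compound 2 or the fluoro and chlorines of compound 1 and compound 3. No independent measurement is available here to account for why the methoxy stands apart from the other groups on this ring.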